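A Second Methoxy Group: Expected Effect on Cytotoxicity

The source may hold more compounds than are shown below. What is called first, only, known or untested is meant among the compounds shown, and "the series" means these compounds.

Three measured compounds share one core and differ only in the groups on one aromatic ring. In a toxicity assay on WI-38 cells (Homo sapiens) for cytotoxicity, read by MTT assay, with a stated time of 48 h (on this read-out lower numbers stand for stronger inhibition and higher numbers for weaker inhibition), compound 1 `O=C(/C=C/c1ccc2c(c1)B(O)OC2)c1ccccc1` gives 19100 nM. Compound 2 `O=C(/C=C/c1ccc2c(c1)B(O)OC2)c1ccccc1O` reaches only the limit of this assay, > 100000 nM. Compound 3 `COc1ccccc1C(=O)/C=C/c1ccc2c(c1)B(O)OC2` gives 21700 nM, which sits within the scatter of compound 1. Compound 4 `COc1ccc(C(=O)/C=C/c2ccc3c(c2)B(O)OC3)c(OC)c1` differs from compound 3 by methoxy in place of hydrogen on an aromatic carbon. The step that bears most directly on this change is a 1.1-fold higher number from compound 1 to compound 3 (0.06 log units; within the scatter), where the same group entered without effect beyond the scatter; by contrast an at least 5.2-fold higher number from compound 1 to compound 2 (0.71 log units; beyond the scatter) moved the number to the limit (the limit of > 100000 nM in this assay, at which 1 of the 3 values shown sits). A step within the scatter is therefore expected, a 1.2-fold higher number from compound 3 to compound 4 (0.06 log units; within the scatter). Compound 4 is estimated at 25000 nM, ranging from 10000 nM to 80000 nM.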

Compound 4, half-maximal inhibitory concentration: 86300 nM
Beside the measured number, compound 4's estimate is 3.5-fold (0.54 log units) below it; the measured number lies above the stated range.
By their numbers in this assay, from the lowest: compounds 1 and 3 (each within the scatter of the next); then compound 4. At a limit, above all of these: compound 2.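

In this assay, methoxy in place of hydrogen on an aromatic carbon is not always a change without effect: here, para to a large group and meta to a methoxy group, the step is a 4.0-fold higher number from compound 3 to compound 4 (0.60 log units; beyond the scatter), whereas the earlier methoxy step was a 1.1-fold higher number from compound 1 to compound 3 (0.06 log units; within the scatter). So the outcome of this change differs between these two cases on the same ring. Compound 4 still gives a measured number, and compound 2 alone stands at a limit of the assay: the limit of > 100000 nM in this assay, at which 1 of the 4 values shown sits.

The compounds shown leave open whether a methoxy group at this position would give the same step without the first methoxy group. Going by these compounds, how an amine or a fluorine atom would read at this position also remains open.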